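The compounds below may be only part of what the source reports. "The series", "measured", "known", "first", "only" and "open" are said of these compounds alone.

In a functional assay on HCT-8 cells (Homo sapiens) for cytotoxicity (on this read-out lower numbers stand for an effect already at smaller amounts and higher numbers for an effect only at larger amounts of compound), the measured compounds read as follows.

- compound 1 `COC1=C(C)C(=O)/C(=C(O)/C=C/c2ccc(O)cc2)C(=O)C1(C)C` gives 14.8 ug/mL
- compound 2 `COC1=C(C)C(=O)/C(=C(O)/C=C/c2ccc(F)cc2)C(=O)C1(C)C` gives 3.6 ug/mL
- compound 3 `CCc1ccc(/C=C/C(O)=C2/C(=O)C(C)=C(OC)C(C)(C)C2=O)cc1` gives 10.5 ug/mL

Compound 3 sits with compound 1 in the upper part of these numbers, since a 1.4-fold lower number from compound 1 to compound 3 (0.15 log units; within the scatter) is no real separation, whereas a 2.9-fold higher number from compound 2 to compound 3 (0.46 log units; beyond the scatter) sets it apart from compound 2. Compound 4 `COC1=C(C)C(=O)/C(=C(O)/C=C/c2c(C)cccc2C)C(=O)C1(C)C` has the same atoms as compound 3, joined differently, and the change is 2,6-dimethylphenyl in place of 4-ethylphenyl on a double-bonded chain carbon bound to a double-bonded chain carbon in the side chain on the shared core.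

The measured steps that bear on this are exchanges on an aromatic carbon. Besides the two above, there is a 4.1-fold lower number from compound 1 to compound 2 (0.61 log units; beyond the scatter) as the largest. None of them involves a 2,6-dimethylphenyl group, so they offer a rough size for an aryl exchange in this series but no direction.

In this assay no step beyond the scatter is expected, and the estimated step is a 1.2-fold lower number from compound 3 to compound 4 (0.07 log units; within the scatter) with real uncertainty either way. Compound 4 is estimated at 9 ug/mL with an expected range from 3.5 ug/mL to 23 ug/mL.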

Compound 4, concentration for half-maximal effect: 7.8 ug/mL
Estimate against measurement, compound 4: 1.2-fold (0.06 log units) above; the range from low to high includes it.
By their numbers in this assay, from the lowest: compound 2; then compounds 4, 3 and 1 (each within the scatter of the next).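

Exchanging 4-ethylphenyl for 2,6-dimethylphenyl on a double-bonded chain carbon bound to a double-bonded chain carbon rearranges the same atoms, and this assay shows a 1.3-fold lower number from compound 3 to compound 4 (0.13 log units; within the scatter) as the outcome, so this rearrangement of the aryl group is not resolved by this read-out. The new compound also stays unseparated from the 4-hydroxyphenyl member, with a 1.9-fold lower number from compound 1 to compound 4 (0.28 log units; within the scatter) on record, while a 2.2-fold higher number from compound 2 to compound 4 (0.34 log units; beyond the scatter) leaves compound 2 apart from all three others at this position. No measurement at hand explains these differences.

Open, on these data alone, is whether the lower number of compound 2 is specific to fluoro or recurs with chloro or methoxy on the aromatic ring. Also open, as far as these compounds go, is how an amine or a carboxylic acid there would read.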